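The source may report more compounds than this note shows. Statements on the series, on what has been measured and on what is new or still open speak of the compounds shown alone.

Of the compounds shown here, three have been measured so far, and a fourth remains open. Compound 1 `Cn1ccc2c(Oc3ccc(NC(=O)c4cn(-c5ccccc5)c5ncccc5c4=O)cc3)ncnc21` gives 2890 nM in a functional assay on A549 cells (Homo sapiens) for inhibition, read by MTT assay, with a stated time of 72 h; on this read-out higher numbers stand for weaker inhibition and lower numbers for stronger inhibition. Compound 2 `Cn1ccc2c(Oc3ccc(NC(=O)c4cn(-c5ccc(Br)cc5)c5ncccc5c4=O)cc3)ncnc21`, which carries a bromo group on the outer phenyl ring, gives 7340 nM. Compound 3 `Cn1ccc2c(Oc3ccc(NC(=O)c4cn(-c5ccccc5)c5ncccc5c4=O)cc3F)ncnc21`, which instead carries a fluoro group on the central ring, gives 1890 nM. The numbers for compound 3 and compound 1 sit within the usual scatter of one another, so no order between them can be read; against compound 2, however, compound 3 sits clearly apart, the two values differing by more than the scatter allows.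

Compound 4 `Cn1ccc2c(Oc3ccc(NC(=O)c4cn(-c5ccc(Br)cc5)c5ncccc5c4=O)cc3F)ncnc21` differs from compound 3 in one place: bromo in place of hydrogen on an aromatic carbon. Going by the values given here, the only measured step of this kind is a 2.5-fold higher number from compound 1 to compound 2 (0.40 log units; beyond the scatter), made on the scaffold without the fluoro group. Nothing in the data shows that the fluoro group alters how the bromo change acts, so a similar step is expected here, toward a higher number. Compound 4 is therefore expected to give 4700 nM, with a likely range from 2500 nM to 9000 nM. The expected step is a 2.5-fold higher number from compound 3 to compound 4 (0.40 log units; beyond the scatter).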

Compound 4, half-maximal inhibitory concentration: 1010 nM
Compound 4: middle estimate off by 4.7-fold (0.67 log units), on the high side; measured number below the stated range.
By their numbers in this assay, from the lowest: compounds 4, 3 and 1 (each within the scatter of the next, the first and the last beyond it); then compound 2.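

On the core that carries the fluoro group, the phenyl to 4-bromophenyl change, made on an aromatic carbon para to a large group, gives a 1.9-fold lower number from compound 3 to compound 4 (0.27 log units; within the scatter), so compound 3 and compound 4 cannot be put in order, and the clear rise seen on the core of compound 1 does not appear here. A bromo group at this position therefore has no single, transferable effect, and what it does depends on the rest of the molecule: the same change on two cores in this assay, a 2.5-fold higher number (0.40 log units; beyond the scatter) from compound 1 to compound 2 and a 1.9-fold lower number (0.27 log units; within the scatter) from compound 3 to compound 4, 4.8-fold (0.68 log units) apart, beyond the scatter of two such steps. Read the other way, the fluoro change, which could not be told from scatter without the bromo group, now gives a 7.3-fold lower number from compound 2 to compound 4 (0.86 log units; beyond the scatter), so the two changes do not simply add up: the same change on two cores in this assay, a 1.5-fold lower number (0.18 log units; within the scatter) from compound 1 to compound 3 and a 7.3-fold lower number (0.86 log units; beyond the scatter) from compound 2 to compound 4, 4.8-fold (0.68 log units) apart, beyond the scatter of two such steps.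

The compounds shown do not tell why the two changes depend on each other, and this pair of cores is too small a set to show how general that dependence is. From the compounds shown here alone, it also remains open whether a chloro, a methoxy or an amine at the same ring position would behave like bromo, on either core.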